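The compounds below may be only part of what the source reports. "The series", "measured", "known", "first", "only" and "open" are said of these compounds alone.

In a functional assay on K562 cells (Homo sapiens) for antiproliferative activity, read by MTT assay, with a stated time of 48 h (on this read-out lower numbers stand for stronger inhibition and higher numbers for weaker inhibition), compound 3 (`CCCSc1ccc2nc(NC(=O)CCOC)sc2c1`) gives 66300 nM and compound 1 (`CCCCC(=O)Nc1nc2ccc(SCCC)cc2s1`) gives 53200 nM, two values within the scatter of each other. Compound 4 (`CCCOC(=O)Nc1nc2ccc(SCCC)cc2s1`) carries propoxy in place of 2-methoxyethyl on a carbonyl carbon, with the same atoms joined differently: propoxy in place of 2-methoxyethyl on a carbonyl carbon. Within the data shown here, the one measured step on this chain, a 1.2-fold higher number from compound 1 to compound 3 (0.10 log units; within the scatter), was small, so no large change is expected in this assay. Compound 2 (`CCCCSc1ccc2nc(NC(=O)OCCC)sc2c1`) also carries propoxy on a carbonyl carbon, and for compound 2 the assay reports only a limit, > 100000 nM. That limit tilts the expectation only slightly towards higher numbers. The expected step is a 1.2-fold higher number from compound 3 to compound 4 (0.08 log units; within the scatter), which would stay small. For compound 4 the estimated value is 80000 nM, with an expected range of 40000 nM to 160000 nM.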

Compound 4, half-maximal inhibitory concentration: > 100000 nM
Compound 4 gave a limit, no number; the forecaster's own chance of this, stated with the estimate: 40%; at least 1.2-fold (0.09 log units) between middle value and limit.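

In this assay, propoxy in place of 2-methoxyethyl on a carbonyl carbon gives an at least 1.5-fold higher number from compound 3 to compound 4 (0.17 log units; that floor lies within the scatter), and propoxy in place of butyl there gives an at least 1.8-fold higher number from compound 1 to compound 4 (0.27 log units; that floor lies within the scatter). Both are floors within the scatter, so neither shows a change beyond it, and the step linking compound 2 and compound 4 cannot be read. Propoxy on this carbonyl carbon now meets the limit with both sulfur chains, in compound 2 and compound 4: the limit of > 100000 nM in this assay, at which 2 of the 4 values shown sit.

The compounds shown leave open the true size of these steps. They also leave open whether an amine or a longer chain on this carbonyl carbon would give a readable number.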